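This account rests on a few compounds, and the source may have more. Where it says the series, first, only, none or still open, it means among the compounds named here.

Measured in an ADME assay on HepG2 cells (Homo sapiens) for cytotoxicity, read by MTT assay, with a stated time of 24 h; a lower number here means that less compound is tolerated, a higher number that more compound is tolerated:
- Compound 1 `CC(C)=CCC1=C(OCc2cn(Cc3ccccn3)nn2)C(=O)c2ccccc2C1=O`: 658000 nM
- Compound 2 `CC(C)=CCC1=C(OCc2cn(-c3cccnc3)nn2)C(=O)c2ccccc2C1=O`: 1030000 nM
- Compound 3 `CC(C)=CCC1=C(OCc2cn(-c3cccc(F)c3)nn2)C(=O)c2ccccc2C1=O`: 265000 nM

Compound 3 has the lowest number of the three. The nearest measured comparison is a 2.5-fold lower number from compound 1 to compound 3 (0.39 log units; beyond the scatter), and the furthest is a 3.9-fold lower number from compound 2 to compound 3 (0.59 log units; beyond the scatter). The remaining pair shows a 1.6-fold higher number from compound 1 to compound 2 (0.19 log units; within the scatter).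

Compound 4 `CC(C)=CCC1=C(OCc2cn(-c3ccc(Cl)cc3)nn2)C(=O)c2ccccc2C1=O` is still unmeasured in this assay. It has 4-chlorophenyl in place of 3-fluorophenyl on an aromatic nitrogen.

Going by the values given here, all three measured steps change the group at this same aromatic nitrogen, so they are the only guide to how much the number moves there. The two steps that reach compound 3 are modest, and each replaces a group containing a pyridine ring. Among the compounds with values here, no measured step exchanges one phenyl group for another, so the size of this change has no direct precedent. Both groups here hold one six-membered aromatic ring of carbon only, so no step beyond the scatter is expected, with at most a slight drift downward.

The anchor is compound 3 at 265000 nM. The estimated change is small: a 1.2-fold lower number from compound 3 to compound 4 (0.06 log units; within the scatter). For compound 4 the expected value is 230000 nM, with an estimated range of 100000 nM to 520000 nM.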

Compound 4, half-maximal cytotoxic concentration: 1150000 nM
Estimate against measurement, compound 4: 5.0-fold (0.70 log units) below; the measured number lies above the stated range.
By their numbers in this assay, from the lowest: compound 3; then compounds 1, 2 and 4 (each within the scatter of the next).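

In this assay, exchanging one halogen-bearing phenyl group for another on this aromatic nitrogen gives a step beyond the scatter (a 4.3-fold higher number from compound 3 to compound 4 (0.64 log units; beyond the scatter)), even though 3-fluorophenyl and 4-chlorophenyl have the same counts of heavy atoms, hydrogen-bond donors and hydrogen-bond acceptors, and each holds a six-membered aromatic ring of carbon only. A ring of carbon only on this nitrogen therefore does not by itself go with a low number: compound 4 stays within the scatter of both pyridine-bearing compounds (a 1.1-fold higher number from compound 2 to compound 4 (0.05 log units; within the scatter); a 1.7-fold higher number from compound 1 to compound 4 (0.24 log units; within the scatter)), and compound 3 alone stands apart from the rest of the series. No measurement at hand accounts for this difference between the two phenyl groups.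

Still open, going by these compounds, is whether the step follows the identity of the halogen or its place on the phenyl ring: the two groups differ in both, and 3-chlorophenyl and 4-fluorophenyl would separate the two. Also open, on these data alone, is how the number responds on this nitrogen to an unsubstituted phenyl, or to a phenyl bearing an amine or a carboxylic acid.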